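Swapping Fluoro for Bromo on the Thiourea Aryl Group

A few compounds are considered here, and "the series" means these few. Any claim that something is new, unique, unknown or untested is made for them only; others in the source may bear on it.

Compound 1 `NC(=O)c1c(NC(=O)c2ccccc2Br)sc2c1CCN(C(=S)Nc1ccccc1F)C2` and compound 2 `NC(=O)c1c(NC(=O)c2ccccc2Br)sc2c1CCN(C(=S)Nc1ccccc1Br)C2` differ in one place: bromo in place of fluoro on an aromatic carbon. Both were tested in a functional assay on MKN-74 cells (Homo sapiens) for antiproliferative activity, with a stated time of 24 h; on this read-out lower numbers stand for stronger inhibition and higher numbers for weaker inhibition. For compound 1 the assay reports only a limit, > 50000 nM, because the value sits at the limit of > 50000 nM in this assay, at which 1 of the 3 values shown sits. Compound 2 gives 13700 nM. That amounts to an at least 3.6-fold lower number from compound 1 to compound 2 (0.56 log units; beyond the scatter).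

Compound 3 `NC(=O)c1c(NC(=O)c2ccccc2C(F)(F)F)sc2c1CCN(C(=S)Nc1ccccc1F)C2` carries a different core from compound 1; the two cores differ in this way: trifluoromethyl in place of bromo on an aromatic carbon. In this assay compound 3 gives 19600 nM, which is an at least 2.5-fold lower number from compound 1 to compound 3 (0.40 log units; beyond the scatter). Compound 2 and compound 3 give numbers that lie within the scatter of each other.

Compound 4 `NC(=O)c1c(NC(=O)c2ccccc2C(F)(F)F)sc2c1CCN(C(=S)Nc1ccccc1Br)C2` has not yet been measured. It differs from compound 3 by bromo in place of fluoro on an aromatic carbon, the same change as that from compound 1 to compound 2, made in the same place. Resting on that earlier step, compound 4 is expected to show a 3.3-fold lower number from compound 3 to compound 4 (0.51 log units; beyond the scatter) in this assay. The estimate for compound 4 is 6000 nM, with an expected range from 2000 nM to 20000 nM. The earlier step starts from a limit, so its true size is not known, and the range is kept wide.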

Compound 4, half-maximal inhibitory concentration: 23900 nM
Estimate against measurement, compound 4: 4.0-fold (0.60 log units) below; the measured number lies above the stated range.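

In this assay, bromo in place of fluoro on the trifluoromethyl core gives a 1.2-fold higher number from compound 3 to compound 4 (0.09 log units; within the scatter), and trifluoromethyl in place of bromo with the 2-bromophenyl group present gives a 1.7-fold higher number from compound 2 to compound 4 (0.24 log units; within the scatter), so neither of these new steps moves the number beyond the scatter. The bromo change therefore does not carry over from the core of compound 1 to the core of compound 3, and its effect in this small set depends on the core: the same change on two cores in this assay, an at least 3.6-fold lower number (0.56 log units; beyond the scatter) from compound 1 to compound 2 and a 1.2-fold higher number (0.09 log units; within the scatter) from compound 3 to compound 4, at least 4.4-fold (0.64 log units) apart, beyond the scatter of two such steps. Compound 1 has only a limit, > 50000 nM, so the true size of this gap is unknown, and nothing here says why the two cores behave differently.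

The compounds shown leave open how other groups at the same place on the thiourea aryl ring would behave, such as chloro, methoxy or an amine. As far as these compounds go, it also remains open whether either core would respond to such groups as the core of compound 1 did or as the core of compound 3 did.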